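Benzyl in place of isopropyl on the compound 1 scaffold

This account rests on a few compounds, and the source may have more. Where it says the series, first, only, none or still open, it means among the compounds named here.

Measured so far:
compound 1 `CO/N=c1\[nH]cnc2c1[n+](C/C=C(\C)CC/C=C(\C)CC/C=C(\C)CCC=C(C)C)cn2C(C)C`: 1100 nM
compound 2 `CC(C)=CCC/C(C)=C/CC/C(C)=C/CC/C(C)=C/C[n+]1cn(CCC#N)c2nc[nH]/c(=N\OCc3ccccc3)c21`: 24200 nM

Both values come from a functional assay on U-937/GTB cells (Homo sapiens) for cytotoxicity; a lower number here means a stronger inhibitor, a higher number a weaker inhibitor. Compound 1 holds the lower number of the two at 1100 nM, while compound 2 stands higher at 24200 nM, a gap beyond the scatter. These two compounds differ in more than one place, so their gap cannot be assigned to any single change.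

The next compound to be measured is compound 3 `CO/N=c1\[nH]cnc2c1[n+](C/C=C(\C)CC/C=C(\C)CC/C=C(\C)CCC=C(C)C)cn2Cc1ccccc1`, which keeps the rest of compound 1 and carries benzyl in place of isopropyl on an aromatic nitrogen. Among the compounds with values here, no measured pair isolates this change, so the expectation has little direct support and starts from compound 1 at 1100 nM. In this assay a small upward step is expected, no larger than the scatter, though the uncertainty is wide. The estimated step is a 1.4-fold higher number from compound 1 to compound 3 (0.13 log units; within the scatter). For compound 3 the expected value is 1500 nM, with an estimated range from 500 nM to 6000 nM.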

Compound 3, half-maximal inhibitory concentration: 1070 nM
The estimate for compound 3 lay 1.4-fold (0.15 log units) above the measured number, and the stated range covers the measured number.
By their numbers in this assay, from the lowest: compounds 3 and 1 (each within the scatter of the next); then compound 2.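

In this assay, within the data shown here, benzyl in place of isopropyl on the aromatic nitrogen of the five-membered ring gives a 1.0-fold lower number from compound 1 to compound 3 (0.01 log units; within the scatter) and is the first pair to isolate this position. With the rest of compound 1 held constant, 7 heavy atoms including one six-membered aromatic ring of carbon only stand in place of 3 heavy atoms and no ring, and the two values remain within the scatter of each other. No measurement at hand accounts for this result.

From the compounds shown here alone, the reading rests on one pair in one cell assay, so it remains open whether an amine, a carboxylic acid or a longer chain on this nitrogen would also stay within the scatter of compound 1. The higher number of compound 2 also remains unassigned, since compound 2 differs from both compound 1 and compound 3 in more than one place.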